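This account rests on a few compounds, and the source may have more. Where it says the series, first, only, none or still open, it means among the compounds named here.

Measured compounds:
Compound 1 `Cc1ccc(S(=O)(=O)Oc2ccc3c(c2C)[C@H](Cn2cc(-c4ccc(Br)cc4)nn2)[C@@]24CC(=O)[C@@](C)(CC[C@@H]32)C4)cc1`. In a functional assay on SW480 cells (Homo sapiens) for cytotoxicity, read by MTT assay, with a stated time of 4 days (a higher number here means a weaker inhibitor, a lower number a stronger inhibitor), compound 1 gives > 20000 nM, which is a limit of the assay and not a number.
Compound 2 `Cc1ccc(-c2cn(C[C@H]3c4c(ccc(OS(=O)(=O)c5ccc(C)cc5)c4C)[C@@H]4CC[C@@]5(C)C[C@]43CC5=O)nn2)cc1`. In this assay compound 2 gives > 20000 nM, again a limit and not a number.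
Compound 3 `Cc1ccc(S(=O)(=O)Oc2ccc3c(c2C)[C@H](Cn2cc(-c4ccc(C(F)(F)F)cc4)nn2)[C@@]24CC(=O)[C@@](C)(CC[C@@H]32)C4)cc1`. In this assay compound 3 gives > 20000 nM, also a limit and not a number.

Compound 3 therefore stands at the same limit as the two other measured compounds, and nothing separates the three on the numbers shown (the limit of > 20000 nM in this assay, at which 3 of the 3 values shown sit). Among the compounds with values here, the measured steps are all between limits: a step that the two limits leave unreadable from compound 1 to compound 2, a step that the two limits leave unreadable from compound 1 to compound 3 and a step that the two limits leave unreadable from compound 2 to compound 3; none of them has a readable size, so no step in this assay has been seen to move a value of this core off the limit.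

The next compound is compound 4 `Cc1ccc(S(=O)(=O)Oc2ccc3c(c2C)[C@H](Cn2cc(-c4ccc(F)cc4)nn2)[C@@]24CC(=O)[C@@](C)(CC[C@@H]32)C4)cc1`. Its change from compound 3 is fluoro in place of trifluoromethyl on an aromatic carbon. All three measured steps bear on it only in that each exchange of the group on that aromatic carbon left the value at the limit. The expectation is therefore a step of no readable size, a step that the limit leaves unreadable from compound 3 to compound 4, with compound 4 most likely reported again as a limit. Compound 4 is estimated at 25000 nM in this assay, within a range from 12000 nM to 60000 nM.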

Compound 4, half-maximal inhibitory concentration: > 20000 nM
Compound 4 gave a limit, no number (the forecaster's own chance of this, stated with the estimate: 85%); the middle value is on the limit's open side.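

Compound 4 also gives a limit and not a number, so none of the steps among compound 1, compound 2, compound 3 and compound 4 can be read: the limit of > 20000 nM in this assay, at which 4 of the 4 values shown sit. The compounds shown leave open whether any other group on that aromatic carbon, or any change elsewhere on the shared core, gives a value off the limit in this assay.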